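Swapping a thiophene for a pyrrole on the enone carbonyl

This account rests on a few compounds, and the source may have more. Where it says the series, first, only, none or still open, it means among the compounds named here.

Measured compounds:
- compound 1 `COc1ccc(-c2cc3ccccc3nc2/C=C/C(=O)c2c(OC)cccc2OC)cc1`: 4520 nM
- compound 2 `COc1ccc(-c2cc3ccccc3nc2/C=C/C(=O)c2ccco2)cc1`: 710 nM
- compound 3 `COc1ccc(-c2cc3ccccc3nc2/C=C/C(=O)c2ccsc2)cc1`: 6010 nM

In a functional assay on MCF7 cells (Homo sapiens) for antiproliferative activity, read by XTT assay, with a stated time of 72 h (on this read-out lower numbers stand for stronger inhibition and higher numbers for weaker inhibition), compound 3 gives the highest number of the three; the step of a 1.3-fold higher number from compound 1 to compound 3 (0.12 log units; within the scatter) is within the scatter, while the step of an 8.5-fold higher number from compound 2 to compound 3 (0.93 log units; beyond the scatter) is beyond it. Compound 4 `COc1ccc(-c2cc3ccccc3nc2/C=C/C(=O)c2ccc[nH]2)cc1` differs from compound 3 by one change: 1H-pyrrol-2-yl in place of thiophen-3-yl on a carbonyl carbon. For the measured compounds named here, the only step that bears on a change of the five-membered ring at this carbonyl is an 8.5-fold higher number from compound 2 to compound 3 (0.93 log units; beyond the scatter), so a ring that, like furan-2-yl, joins the carbonyl through the atom next to the hetero atom is expected to give a lower number in this assay. Compound 4 is therefore expected to land at about 1500 nM, within 400 nM to 5500 nM, a step of a 4.0-fold lower number from compound 3 to compound 4 (0.60 log units; beyond the scatter).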

Compound 4, half-maximal inhibitory concentration: > 10000 nM
Compound 4: a limit, no number; the forecaster's own chance of this, stated with the estimate: 5%; middle value at least 6.6-fold (0.82 log units) away from the limit.
By their numbers in this assay, from the lowest: compound 2; then compounds 1 and 3 (each within the scatter of the next). At a limit, above all of these: compound 4.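

In this assay compound 4 gives > 10000 nM, which is a limit and not a number. Sharing a five-membered aromatic ring on the carbonyl carbon is therefore not enough to keep the level of compound 2, as 1H-pyrrol-2-yl falls well short of furan-2-yl (an at least 14-fold higher number from compound 2 to compound 4 (1.14 log units; beyond the scatter)) and also of 2,6-dimethoxyphenyl (an at least 2.2-fold higher number from compound 1 to compound 4 (0.34 log units; beyond the scatter)). Compared with thiophen-3-yl, no order can be claimed (an at least 1.6-fold higher number from compound 3 to compound 4 (0.22 log units; that floor lies within the scatter)).

Still open, on these data alone, is how far compound 4 lies past its limit. Also open, as far as these compounds go, is whether thiophen-2-yl, or a methyl group on the pyrrole nitrogen, would restore the level of compound 2.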